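The compounds below may be only part of what the source reports. "The series", "measured", "known", "first", "only" and "open" are said of these compounds alone.

Measured in a functional assay on MCF7 cells (Homo sapiens) for antiproliferative activity; a higher number here means a weaker inhibitor of growth, a lower number a stronger inhibitor of growth:
- compound 1 `Cc1cc(-c2nc3ccccc3s2)ccc1N`: < 0.1 nM (a limit)
- compound 2 `COc1ccc(-c2nc3cc(F)ccc3s2)cc1F`: 870 nM
- compound 3 `Oc1ccc(-c2nc3cc(F)ccc3s2)cc1O`: 720 nM

Compound 2 stands level with compound 3, the two numbers lying within the scatter of each other. Compound 1 stands at a limit of the assay, < 0.1 nM.

Compound 4 `COc1ccc(-c2nc3cc(F)ccc3s2)cc1OC` carries methoxy in place of fluoro on an aromatic carbon, ortho to a methoxy group and meta to a large group (methoxy in place of fluoro on an aromatic carbon).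

Among the compounds with values here, no measured step guides this change, so the expectation is loose. A large downward step in this assay is expected, an 870-fold lower number from compound 2 to compound 4 (2.94 log units; beyond the scatter), given how far the series reaches with compound 1 at < 0.1 nM. The estimate for compound 4 is 1 nM, with an expected range of 0.05 nM to 500 nM.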

Compound 4, concentration for 50% growth inhibition: < 0.1 nM
Compound 4 ended at the assay's limit; the forecaster's own chance of this, stated with the estimate: 50%; at least 10-fold (1.00 log units) between middle value and limit.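

In this assay, methoxy in place of fluoro on this aromatic carbon, ortho to a methoxy group and meta to a large group, gives a single-place change with a large effect: an at least 8700-fold lower number from compound 2 to compound 4 (3.93 log units; beyond the scatter). Compound 4 reads < 0.1 nM, which is a limit and not a number. The full size of the step therefore cannot be read, because the assay stops there: the limit of < 0.1 nM in this assay, at which 2 of the 4 values shown sit.

On these data alone, how an amine or an ethoxy group on this carbon would read remains open. So does whether the step depends on the methoxy group ortho to it.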